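Aryl swap on the pyrrole nitrogen: solubility notes

The compounds below may be only part of what the source reports. "The series", "measured", "known", "first", "only" and "open" are said of these compounds alone.

Compound 1, `CCOC(=O)C1=C(C)N/C(=C/c2cc(C)n(-c3ccc(F)cc3F)c2C)C1=O`, gives 6.3 ug/mL in a physicochemical assay for solubility, read by nephelometry, in phosphate buffer, measured as kinetic solubility, at pH 6.5; a higher number here means a more soluble compound, a lower number a less soluble compound.
Compound 2, `CCOC(=O)C1=C(C)N/C(=C/c2cc(C)n(-c3cccc(OC)c3)c2C)C1=O`, gives in this assay only a limit, < 1.6 ug/mL.
Compound 3, `CCOC(=O)C1=C(C)N/C(=C/c2cc(C)n(-c3ccc(SC)cc3)c2C)C1=O`, gives 1.6 ug/mL in this assay.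

Compound 3 holds the lowest of the two numbers shown; the other value is a limit, (the limit of < 1.6 ug/mL in this assay, at which 1 of the 3 values shown sits). The measured steps are a 3.9-fold lower number from compound 1 to compound 3 (0.60 log units; beyond the scatter), an at least 3.9-fold lower number from compound 1 to compound 2 (0.59 log units; beyond the scatter) and a number no lower from compound 2 to compound 3 (the limit leaves the size open).

Compound 4, `CCOC(=O)C1=C(C)N/C(=C/c2cc(C)n(-c3ccncc3)c2C)C1=O`, differs from compound 3 by pyridin-4-yl in place of 4-(methylsulfanyl)phenyl on an aromatic nitrogen. Within the data shown here, both readable steps replace the 2,4-difluorophenyl with another carbon-only ring, so no measured step tries a ring hetero atom here; the direction is therefore open. A step no larger than the scatter, with some upward room, is expected: a 2.2-fold higher number from compound 3 to compound 4 (0.34 log units; beyond the scatter). Compound 4 is estimated at 3.5 ug/mL, between 1.2 ug/mL and 12 ug/mL.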

Compound 4, solubility: 50 ug/mL
Compound 4: middle estimate off by 14-fold (1.15 log units), on the low side, and the stated range ends below it.
By their numbers in this assay, from the lowest: compound 3; then compound 1; then compound 4.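

Pyridin-4-yl is the only group shown on this aromatic nitrogen with a hetero atom in its ring, and in this assay it gives a 31-fold higher number from compound 3 to compound 4 (1.49 log units; beyond the scatter) in the large range. The same change also gives a 7.9-fold higher number from compound 1 to compound 4 (0.90 log units; beyond the scatter) and so reverses the direction of the earlier readable steps, which all lowered the number. The step of an at least 31-fold higher number from compound 2 to compound 4 (1.49 log units; beyond the scatter) has no fixed size, and compound 2 gives only a limit: the limit of < 1.6 ug/mL in this assay, at which 1 of the 4 values shown sits.

On these data alone, whether pyridin-3-yl or a pyrimidine ring would behave like pyridin-4-yl remains open. So does whether a phenyl bearing a dimethylamino group would reach compound 4.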